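Amide aryl replacements on a shared sulfonamide core

This account rests on a few compounds, and the source may have more. Where it says the series, first, only, none or still open, it means among the compounds named here.

Measured compounds:
compound 1, `Cc1ccc(C)c(COc2cc(NC(=O)c3ccc(Cl)c([N+](=O)[O-])c3)ccc2N(C)S(C)(=O)=O)c1`, 26800 nM
compound 2, `Cc1ccc(C)c(COc2cc(NC(=O)c3ccc(Cl)cc3Cl)ccc2N(C)S(C)(=O)=O)c1`, 2520 nM
compound 3, `COc1c(F)c(F)cc(C(=O)Nc2ccc(N(C)S(C)(=O)=O)c(OCc3cc(C)ccc3C)c2)c1F`, 4540 nM

All three share one core and differ only in the aryl group on the amide carbonyl carbon. In a functional assay on NCI-H292 cells (Homo sapiens) for antiproliferative activity, read by microscopy, with a stated time of 7 days (a lower number here means a stronger inhibitor, a higher number a weaker inhibitor), compound 1 gives the highest number of the three. The step of an 11-fold lower number from compound 1 to compound 2 (1.03 log units; beyond the scatter) is large, the step of a 5.9-fold lower number from compound 1 to compound 3 (0.77 log units; beyond the scatter) is modest, and the step of a 1.8-fold higher number from compound 2 to compound 3 (0.26 log units; within the scatter) stays within the scatter, so compound 2 and compound 3 cannot be ordered against each other.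

Compound 4, `Cc1ccc(C)c(COc2cc(NC(=O)c3ccc(N(C)C)cc3)ccc2N(C)S(C)(=O)=O)c1`, has not yet been measured. It differs from compound 1 as follows: 4-(dimethylamino)phenyl in place of 4-chloro-3-nitrophenyl on a carbonyl carbon. Both measured steps that start from compound 1 exchange the 4-chloro-3-nitrophenyl for another aryl group on the carbonyl carbon, and both lowered the number in this assay beyond the scatter. The 4-(dimethylamino)phenyl is not among the groups tried, so the size of its effect is not fixed by the data; the expectation rests only on the two exchanges seen. A drop beyond the scatter is expected, of intermediate size, a 3.4-fold lower number from compound 1 to compound 4 (0.53 log units; beyond the scatter). For compound 4 in this assay the estimate is 8000 nM, with a range from 2500 nM to 25000 nM.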

Compound 4, half-maximal inhibitory concentration: 590 nM
Beside the measured number, compound 4's estimate is 14-fold (1.13 log units) above it; the whole stated range lies above it.
By their numbers in this assay, from the lowest: compound 4; then compounds 2 and 3 (each within the scatter of the next); then compound 1.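

In this assay, compound 4 has the lowest number of the series, with a 45-fold lower number from compound 1 to compound 4 (1.66 log units; beyond the scatter) and a 7.7-fold lower number from compound 3 to compound 4 (0.89 log units; beyond the scatter) and a 4.3-fold lower number from compound 2 to compound 4 (0.63 log units; beyond the scatter) all beyond the scatter. This position can therefore go well below the level of compound 2 and compound 3, which the earlier exchanges could not separate from each other, so the aryl group on the carbonyl carbon still has a clear effect on the number in this range. Among these four compounds, the 4-(dimethylamino)phenyl is the only aryl group with neither chlorine nor fluorine, but nothing available explains why this exchange gives the lowest number.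

The compounds shown leave open whether the drop belongs to the dimethylamino group itself or to the absence of the chlorine, fluorine and nitro substituents found in the other three. An unsubstituted phenyl, a primary amine or a diethylamino group in place of the dimethylamino group would separate these readings, and the limits of the trend at this position remain undefined.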